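Compound 3 and a change of ring size

A few compounds are considered here, and "the series" means these few. Any claim that something is new, unique, unknown or untested is made for them only; others in the source may bear on it.

Measured in a functional assay on HeLa cells (Homo sapiens) for cytotoxicity, read by MTT assay; on this read-out lower numbers stand for stronger inhibition and higher numbers for weaker inhibition:
- compound 1 `CC(C)=CC[C@@H](OC[C@H](C)O)C1=CC(=O)c2c(O)ccc(O)c2C1=O`: 40300 nM
- compound 2 `CC(C)=CC[C@@H](OC(=O)CC(O)c1ccccc1)C1=CC(=O)c2c(O)ccc(O)c2C1=O`: 44500 nM
- compound 3 `CC(C)=CC[C@@H](OC(=O)C1CCCO1)C1=CC(=O)c2c(O)ccc(O)c2C1=O`: 17000 nM

Compound 3 has the lowest number of the three. Two measured steps lead to it, and both are modest: a 2.4-fold lower number from compound 1 to compound 3 (0.37 log units; beyond the scatter) and a 2.6-fold lower number from compound 2 to compound 3 (0.42 log units; beyond the scatter). Compound 4 `CC(C)=CC[C@@H](OC(=O)C1CCCCO1)C1=CC(=O)c2c(O)ccc(O)c2C1=O` differs from compound 3 in one group, with oxan-2-yl in place of oxolan-2-yl on a carbonyl carbon. Within the data shown here, those two steps exchanged quite different groups, so they bear on this change only loosely, and no measured pair tests ring size alone. No step beyond the scatter is therefore expected in this assay. The estimated step is a 1.1-fold higher number from compound 3 to compound 4 (0.05 log units; within the scatter). Compound 4 is estimated at 19000 nM, with an expected range from 8500 nM to 42000 nM.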

Compound 4, half-maximal inhibitory concentration: > 100000 nM
Compound 4 was reported as a limit; the forecaster's own chance of this, stated with the estimate: 5%; at least 5.2-fold (0.72 log units) between middle value and limit.
By their numbers in this assay, from the lowest: compound 3; then compounds 1 and 2 (each within the scatter of the next). At a limit, above all of these: compound 4.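

In this assay, compound 4 is known only as a limit: the limit of > 100000 nM in this assay, at which 1 of the 4 values shown sits. Swapping oxolan-2-yl for oxan-2-yl on this carbonyl carbon gives an at least 5.8-fold higher number from compound 3 to compound 4 (0.76 log units; beyond the scatter), so ring size here matters, although the true size of the step stays unknown. The larger ring also falls behind both other groups, with an at least 2.2-fold higher number from compound 2 to compound 4 (0.35 log units; beyond the scatter) and an at least 2.4-fold higher number from compound 1 to compound 4 (0.39 log units; beyond the scatter).

The compounds shown do not tell why the ring size matters. From the compounds shown here alone, it also remains open how a smaller oxetan-2-yl ring, or a pyrrolidin-2-yl ring carrying nitrogen instead of oxygen, would compare with compound 3.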